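Amide substituent variation on the shared ribose-carboxamide core

The source may hold more compounds than are shown below. What is called first, only, known or untested is meant among the compounds shown, and "the series" means these compounds.

Measured so far:
Compound 1 `CCCCCCCNC(=O)[C@H]1OC(n2cnc3c(N)ncnc32)[C@H](O)[C@@H]1O` gives 20 nM in an assay on cell membranes for binding affinity to 2-oxoglutarate receptor 1 (Rattus norvegicus), read by radioligand binding; a higher number here means a weaker inhibitor, a lower number a stronger inhibitor.
Compound 2 `CCC(C)NC(=O)[C@H]1OC(n2cnc3c(N)ncnc32)[C@H](O)[C@@H]1O` gives 198 nM in this assay.

Compound 2 stands highest of the two numbers; its nearest neighbour is compound 1, and the step between them is a 9.9-fold higher number from compound 1 to compound 2 (1.00 log units; beyond the scatter). Compound 3 `Nc1ncnc2c1ncn2C1O[C@H](C(=O)NC2CC3CCC2C3)[C@@H](O)[C@H]1O` differs from compound 2 as follows: a group of 7 heavy atoms (7 carbon; 2 five-membered non-aromatic rings of carbon only) in place of a group of 4 heavy atoms (4 carbon; no ring), on an amide-type nitrogen. For the measured compounds named here, the only measured step bearing on this change is a 9.9-fold higher number from compound 1 to compound 2 (1.00 log units; beyond the scatter), where sec-butyl in place of heptyl gave the higher number; the group entering in compound 3 is as large as heptyl in heavy atoms but built of rings. A step toward a lower number is therefore expected, a 4.0-fold lower number from compound 2 to compound 3 (0.60 log units; beyond the scatter), with its size uncertain. Compound 3 is estimated at 50 nM, range 12 nM to 200 nM.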

Compound 3, inhibition constant: 640 nM
Compound 3: the middle estimate sits 13-fold (1.11 log units) below what was measured; the whole stated range lies below it.
By their numbers in this assay, from the lowest: compound 1; then compound 2; then compound 3.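

In this assay, the count of heavy atoms on the amide-type nitrogen does not by itself set the number: at an equal count, replacing heptyl with the two-ring group gives a 32-fold higher number from compound 1 to compound 3 (1.51 log units; beyond the scatter) beyond the scatter. The ring-built group also stands behind the smaller sec-butyl, with a 3.2-fold higher number from compound 2 to compound 3 (0.51 log units; beyond the scatter) as the step, so the three compounds do not order by group size. No measured evidence accounts for either step.

Open, on these data alone, is how a cyclohexyl group or a chain longer than heptyl would stand on this nitrogen. Also open, as far as these compounds go, is whether the higher number holds for other ring-built groups.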